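The source may hold more compounds than are shown below. What is called first, only, known or untested is meant among the compounds shown, and "the series" means these compounds.

Of the compounds shown here, three built on one shared core have been tested in a functional assay on THP-1 cells (Homo sapiens) for cytotoxicity, read by MTT assay, with a stated time of 72 h; a lower number here means a stronger inhibitor, a higher number a weaker inhibitor. Compound 1 `C=C1C2=C(C(=O)N1OC)[C@H](OC(=O)CSc1nc3ccccc3s1)[C@@](C)(O)[C@H](CCCCC)O2` gives 1600 nM. Compound 2 `C=C1C2=C(C(=O)N1OC)[C@H](OC(=O)CSc1nc3ccccc3o1)[C@@](C)(O)[C@H](CCCCC)O2` gives 2300 nM, the second highest of the three numbers; compound 1 is its nearest neighbour, while compound 3 `C=C1C2=C(C(=O)N1OC)[C@@H](F)[C@@](C)(O)[C@H](CCCCC)O2`, which gives 19000 nM, lies beyond the scatter above it. Among the measured compounds shown here, the one step that swaps a ring pair on the sulfur, a 1.4-fold higher number from compound 1 to compound 2 (0.16 log units; within the scatter), stays within the scatter. Compound 4 `C=C1C2=C(C(=O)N1OC)[C@H](OC(=O)CSc1nc3ccccc3[nH]1)[C@@](C)(O)[C@H](CCCCC)O2` differs from compound 2 by 1H-benzimidazol-2-yl in place of 1,3-benzoxazol-2-yl on a sulfur. Because a 1.4-fold higher number from compound 1 to compound 2 (0.16 log units; within the scatter) barely moved the number, a step of about a 1.2-fold lower number from compound 2 to compound 4 (0.06 log units; within the scatter) is expected, nothing beyond the scatter. Compound 4 is therefore estimated at 2000 nM, with a range from 900 nM to 4500 nM.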

Compound 4, half-maximal inhibitory concentration: 5300 nM
Beside the measured number, compound 4's estimate is 2.7-fold (0.42 log units) below it, and the stated range ends below it.
By their numbers in this assay, from the lowest: compounds 1 and 2 (each within the scatter of the next); then compound 4; then compound 3.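

At this position on the sulfur, the ring is not interchangeable after all: in this assay, 1H-benzimidazol-2-yl gives a 2.3-fold higher number from compound 2 to compound 4 (0.36 log units; beyond the scatter) and a 3.3-fold higher number from compound 1 to compound 4 (0.52 log units; beyond the scatter) and both steps lie beyond the scatter. Of these three rings, only 1H-benzimidazol-2-yl carries a hydrogen-bond donor, yet that alone does not show what drives the change. No supporting measurement explains the shift. Going by these compounds, what 1-methyl-1H-benzimidazol-2-yl, a plain amine or a carboxylic acid would give on this sulfur remains open.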